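Methylating the Pyrazole of Compound 3

A few compounds are considered here, and "the series" means these few. Any claim that something is new, unique, unknown or untested is made for them only; others in the source may bear on it.

Compound 3 `Cc1cc(C)c(-c2c[nH]nc2C)cc1NC(=O)c1ccc(OCc2ccccn2)cc1` gives 33000 nM in a physicochemical assay for solubility, at pH 7.4 (a lower number here means a less soluble compound, a higher number a more soluble compound), the highest of the two numbers shown. Compound 1 `Cc1cc(C)c(-c2ncc[nH]2)cc1NC(=O)c1ccc(OCc2ccccn2)cc1` gives 2000 nM in this assay. Compound 2 `Cc1cc(C)c(-c2nc3ccccc3[nH]2)cc1NC(=O)c1ccc(OCc2ccccn2)cc1` gives < 1000 nM in this assay, which is a limit of the assay rather than a number, sitting at the limit of < 1000 nM in this assay, at which 1 of the 3 values shown sits. The measured steps toward compound 3 were large: a 17-fold higher number from compound 1 to compound 3 (1.22 log units; beyond the scatter) and an at least 33-fold higher number from compound 2 to compound 3 (1.51 log units; beyond the scatter). Compound 4 `Cc1cc(C)c(-c2c(C)nn(C)c2C)cc1NC(=O)c1ccc(OCc2ccccn2)cc1` differs from compound 3 by 1,3,5-trimethyl-1H-pyrazol-4-yl in place of 3-methyl-1H-pyrazol-4-yl on an aromatic carbon. Going by the values given here, both measured steps exchange one five-membered ring for a different one, whereas this change keeps the pyrazole and adds methyl groups, so no measured step bears directly on it. A moderate lowering in this assay is expected, a 3.3-fold lower number from compound 3 to compound 4 (0.52 log units; beyond the scatter). Compound 4 is therefore estimated at 10000 nM, with a range from 2500 nM to 40000 nM.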

Compound 4, solubility: 35000 nM
Beside the measured number, compound 4's estimate is 3.5-fold (0.54 log units) below it; the range from low to high includes it.
By their numbers in this assay, from the lowest: compound 1; then compounds 3 and 4 (each within the scatter of the next). At a limit, below all of these: compound 2.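

The step to 1,3,5-trimethyl-1H-pyrazol-4-yl gives no separable difference in this assay, with a 1.1-fold higher number from compound 3 to compound 4 (0.03 log units; within the scatter), so on this aromatic carbon the number stays high with or without a hydrogen-bond donor on the ring. The pyrazole of compound 4 also keeps the large gap over the imidazole, with an 18-fold higher number from compound 1 to compound 4 (1.24 log units; beyond the scatter). Compound 2 stands at a limit of the assay, so an at least 35-fold higher number from compound 2 to compound 4 (1.54 log units; beyond the scatter) is only a floor: the limit of < 1000 nM in this assay, at which 1 of the 4 values shown sits.

Which of the added methyl groups matters cannot be told from compound 3 and compound 4 alone. On these data alone, how an amine or a carboxylic acid on the pyrazole would read in this assay remains open.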